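A few compounds are considered here, and "the series" means these few. Any claim that something is new, unique, unknown or untested is made for them only; others in the source may bear on it.

Measured so far:
compound 1, `CCCCCNC(=O)n1c(-c2ccccc2)coc1=O`: 25 nM
compound 2, `O=C(NCCCCc1ccccc1)n1cc(-c2ccc(Cl)cc2)oc1=O`: 83 nM

In an assay on isolated protein for inhibition of acid ceramidase (Homo sapiens), read by LC-MS, with a stated time of 1 h (a lower number here means a stronger inhibitor, a higher number a weaker inhibitor), compound 1 gives 25 nM and compound 2 gives 83 nM. Of these two numbers compound 2 holds the higher one, so it is the weaker inhibitor of the pair, and its gap to compound 1 lies beyond the usual scatter. Going by the values given here, the two compounds differ in several places at once, so no single step can be drawn between them. Compound 3, `O=C(NCCCCc1ccccc1)n1cc(-c2cccnc2)oc1=O`, has not been measured. It keeps the core of compound 2 and changes one group only: pyridin-3-yl in place of 4-chlorophenyl on an aromatic carbon. Among the compounds with values here, no measured pair shows what such a change does here, so the expectation rests on the two numbers alone. The step of a 1.8-fold higher number from compound 2 to compound 3 (0.26 log units; within the scatter) in this assay is expected to be a mild weakening, not clearly beyond the scatter. Compound 3 is estimated at 150 nM, with a range from 50 nM to 500 nM.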

Compound 3, half-maximal inhibitory concentration: 70 nM
The estimate for compound 3 lay 2.1-fold (0.33 log units) above the measured number, within the range that was stated.
By their numbers in this assay, from the lowest: compound 1; then compounds 3 and 2 (each within the scatter of the next).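

In this assay, placing pyridin-3-yl instead of 4-chlorophenyl on the aromatic carbon next to the ring oxygen comes to a 1.2-fold lower number from compound 2 to compound 3 (0.07 log units; within the scatter) and leaves the two compounds indistinguishable. Going by these compounds alone, this is the first single-place comparison: at this position, a carbon-only ring bearing chlorine and a ring with one hetero atom and one hydrogen-bond acceptor give matching results in this assay. Nothing measured here accounts for this outcome.

From the compounds shown here alone, whether a carboxylic acid or an amine at the same position would also leave the number unchanged remains open. Compound 1 differs from compound 2 in several places, so its gap to compound 2 cannot be assigned to any one group.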